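Replacing 4-methoxyphenyl with 3-chlorophenyl in compound 1

This account rests on a few compounds, and the source may have more. Where it says the series, first, only, none or still open, it means among the compounds named here.

compound 1 `COc1ccc(NC(=O)[C@H]2CN(C)C[C@@H]2c2ccc(/C=C/C(=O)Nc3ccccc3N)cc2)cc1`: 54 mL/min/kg
compound 2 `CN1C[C@H](C(=O)Nc2ccc(C#N)cc2)[C@@H](c2ccc(/C=C/C(=O)Nc3ccccc3N)cc2)C1`: 35 mL/min/kg
compound 3 `CN1C[C@H](C(=O)Nc2ccc(C(F)(F)F)cc2)[C@@H](c2ccc(/C=C/C(=O)Nc3ccccc3N)cc2)C1`: 23 mL/min/kg

These three values come from an in vitro ADME assay on microsomes from liver (Mus musculus) for pharmacokinetics, read by LC-MS, with a stated time of 10 min, tested at 1 uM; a higher number here means faster removal of the compound, a lower number slower removal. Compound 1 sits at the top of this small set, though only compound 3 stands clearly apart from it. Compound 4 `CN1C[C@H](C(=O)Nc2cccc(Cl)c2)[C@@H](c2ccc(/C=C/C(=O)Nc3ccccc3N)cc2)C1` carries 3-chlorophenyl in place of 4-methoxyphenyl on an amide-type nitrogen. Two measured steps also remove the methoxy group. Cyano gives a 1.5-fold lower number from compound 1 to compound 2 (0.19 log units; within the scatter), and trifluoromethyl gives a 2.3-fold lower number from compound 1 to compound 3 (0.37 log units; beyond the scatter). Neither step involves chlorine or the 3-chlorophenyl arrangement, so they offer only loose guidance. A modest step in the same direction is therefore expected, a 1.8-fold lower number from compound 1 to compound 4 (0.26 log units; within the scatter), and it may not clear the scatter. Compound 4 is estimated at 30 mL/min/kg, with an expected range from 17 mL/min/kg to 52 mL/min/kg.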

Compound 4, clearance: 58 mL/min/kg
For compound 4 the middle estimate is 1.9-fold (0.29 log units) below the measured one; the measured number lies above the stated range.
By their numbers in this assay, from the lowest: compounds 3, 2, 1 and 4 (each within the scatter of the next, the first and the last beyond it).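

Placing 3-chlorophenyl in place of 4-methoxyphenyl on an amide-type nitrogen gives a 1.1-fold higher number from compound 1 to compound 4 (0.03 log units; within the scatter) and so shows that losing the methoxy group does not by itself lower clearance. Against the trifluoromethyl compound, the same group gives a 2.5-fold higher number from compound 3 to compound 4 (0.40 log units; beyond the scatter) and shows that the aryl group at this position can shift clearance, whereas against the cyano compound it gives a 1.7-fold higher number from compound 2 to compound 4 (0.22 log units; within the scatter) and no separation. Nothing available here accounts for these results. Because the chlorine differs from the earlier groups in both identity and ring position, the compounds shown cannot separate those two changes. From the compounds shown here alone, how 4-chlorophenyl, or an aryl group bearing an amine or a carboxylic acid, would behave remains open.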